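The source may report more compounds than this note shows. Statements on the series, on what has been measured and on what is new or still open speak of the compounds shown alone.

Working notes on the series. Of the compounds shown here, two have been measured in an assay on membranes from brain for binding affinity to adenosine receptor A1 (Rattus norvegicus), read by radioligand binding, tested at 20 uM; on this read-out lower numbers stand for less inhibition and higher numbers for more inhibition at the one concentration tested (going by the name of the read-out). Compound 1, `CCn1c(=O)[nH]c2c(cnn2-c2cccc(Cl)c2)c1=N`, gives 70%. For the measured compounds named here, compound 2, `Cn1c(=O)[nH]c2c(cnn2-c2cccc(Cl)c2)c1=N`, gives 53%, the lowest of the two numbers so far; its nearest neighbour is compound 1, and the step of a number 17 percentage points lower from compound 1 to compound 2 (beyond the scatter) is the only one measured in the set. That step lies at the same place as the change now under consideration, hydrogen in place of methyl on a saturated chain carbon bound to an aromatic nitrogen, and it cost inhibition.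

Compound 3, `CCCCn1c(=O)[nH]c2c(cnn2-c2cccc(Cl)c2)c1=N`, differs from compound 2 by propyl in place of hydrogen on a saturated chain carbon bound to an aromatic nitrogen; read one bond further out, this is methyl to butyl. Going by the values given here, the single measured step bears directly on it: removing one carbon at this position lowered the number beyond the scatter, so adding three carbons at the same position is expected to move this assay upward, by an amount at least comparable to that step. The expected step from compound 2 to compound 3 is therefore a number 21 percentage points higher from compound 2 to compound 3 (beyond the scatter), with the estimate for compound 3 put at 74%, ranging from 55% to 90%.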

Compound 3, a percentage reported as inhibition, at one concentration (the size of the read-out at that concentration, not a potency): 58%
The estimate for compound 3 lay 16 percentage points above the measured number, within the range that was stated.
By their numbers in this assay, from the lowest: compounds 2 and 3 (each within the scatter of the next); then compound 1.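

In this assay, for the compounds shown here, the change of methyl to butyl at this position gives a number 5 percentage points higher from compound 2 to compound 3 (within the scatter), so adding these three carbons does not extend the effect seen in the one earlier step. Adding ethyl to the chain of the ethyl compound gives a number 12 percentage points lower from compound 1 to compound 3 (beyond the scatter), which shows that a longer chain at this position does not bring a steady rise: among the three chains, ethyl gives the highest number, and compound 3 goes against any reading of more carbons as more inhibition. No measurement is at hand that explains this turn in the series.

On these data alone, with only methyl, ethyl and butyl represented, it remains open whether the number falls away gradually beyond ethyl or whether ethyl is an isolated high point, and a straight propyl chain or a branched isopropyl group at this position would help to separate those readings. As far as these compounds go, it is also open whether a chain ending in an amine or a carboxylic acid would behave like the plain chains, and single-concentration numbers of this kind give no potency for any of the compounds.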